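Swapping Halogens on a Phenoxy Arm of a Shared Core

A few compounds are considered here, and "the series" means these few. Any claim that something is new, unique, unknown or untested is made for them only; others in the source may bear on it.

Compound 1 `Nc1cc(N)c2nc(-c3ccccc3)c(Oc3ccc(Cl)c(Cl)c3)nc2c1` was tested in a functional assay on PC-3 cells (Homo sapiens) for inhibition, read by sulforhodamine B assay, with a stated time of 48 h; a lower number here means that less compound is tolerated, a higher number that more compound is tolerated. For compound 1 the result is a limit rather than a number, < 100000 nM. Two further compounds with the same core were run in this assay. Compound 2 `CCOC(=O)[C@H](CCC(=O)O)NC(=O)c1ccc(CNc2nc3cc(N)cc(N)c3nc2-c2ccccc2)cc1` reaches only a limit, < 100000 nM. Compound 3 `CCOC(=O)[C@H](CCC(=O)O)NC(=O)c1ccc(Oc2nc3cc(N)cc(N)c3nc2-c2ccccc2)cc1` likewise gives a limit, < 50200 nM. Compound 1 therefore sits at the limit of < 100000 nM in this assay, at which 2 of the 3 values shown sit, while a tighter bound appears only as the limit of < 50200 nM in this assay, at which 1 of the 3 values shown sits, so no exact position within the series can be given for it.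

Compound 4 `Nc1cc(N)c2nc(-c3ccccc3)c(Oc3ccc(F)cc3)nc2c1` differs from compound 1 in one place: 4-fluorophenyl in place of 3,4-dichlorophenyl on an oxygen on an aromatic ring. Going by the values given here, no measured pair of compounds shows this kind of change, and all three known values are limits, so no direction can be drawn from them. The step from compound 1 to compound 4 is expected to stay within the usual scatter, estimated as a step that the limit leaves unreadable from compound 1 to compound 4. Compound 4 is estimated at 40000 nM, with a range from 5000 nM to 100000 nM, and quite possibly again only a limit.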

Compound 4, concentration lethal to 50% of the cells: 83200 nM
The estimate for compound 4 lay 2.1-fold (0.32 log units) below the measured number; the measured number falls inside the stated range.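

Going by these compounds alone, because the value for compound 1 is only a limit, comparing it with compound 4 gives no step that can be read. The compounds shown leave open how the 3,4-dichlorophenyl and 4-fluorophenyl groups truly compare on the shared core.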